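Aryl variation at the core and microsomal clearance

This account rests on a few compounds, and the source may have more. Where it says the series, first, only, none or still open, it means among the compounds named here.

Measured compounds:
compound 1 `CCn1cc(-c2cc(C(O)(C(F)(F)F)C(F)(F)F)cnc2N2CCN(S(=O)(=O)c3ccc(N)nc3)CC2)cn1`: 20 mL.min-1.g-1
compound 2 `CC(C)(C)n1cc(-c2cc(C(O)(C(F)(F)F)C(F)(F)F)cnc2N2CCN(S(=O)(=O)c3ccc(N)nc3)CC2)cn1`: 86 mL.min-1.g-1
compound 3 `Nc1ccc(S(=O)(=O)N2CCN(c3ncc(C(O)(C(F)(F)F)C(F)(F)F)cc3-c3ccccc3O)CC2)cn1`: 22 mL.min-1.g-1

In an ADME assay (liver) for metabolic stability, with Liver microsome (Homo sapiens) as the target, using microsomes and NADPH, with a stated time of 30 min, tested at 1 uM (a higher number here means faster removal of the compound, a lower number slower removal), compound 3 gives 22 mL.min-1.g-1, which sits close to compound 1 at 20 mL.min-1.g-1 and well under compound 2 at 86 mL.min-1.g-1. Compound 4 `Nc1ccc(S(=O)(=O)N2CCN(c3ncc(C(O)(C(F)(F)F)C(F)(F)F)cc3-c3ccc4ocnc4c3)CC2)cn1` is not yet measured; it differs from compound 3 by 1,3-benzoxazol-5-yl in place of 2-hydroxyphenyl on an aromatic carbon. The two measured steps that touch this position are a 1.1-fold higher number from compound 1 to compound 3 (0.04 log units; within the scatter) and a 3.9-fold lower number from compound 2 to compound 3 (0.59 log units; beyond the scatter). One of these is within the scatter and one is modest; neither involves 1,3-benzoxazol-5-yl, so they give only a rough guide. Compound 4 is therefore expected to show a 1.4-fold higher number from compound 3 to compound 4 (0.13 log units; within the scatter), no clear move beyond the scatter in this assay. The estimate for compound 4 is 30 mL.min-1.g-1, with a range from 12 mL.min-1.g-1 to 75 mL.min-1.g-1.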

Compound 4, intrinsic clearance in microsomes: < 14 mL.min-1.g-1
Compound 4 was reported as a limit; the forecaster's own chance of this, stated with the estimate: 3%; middle value at least 2.1-fold (0.33 log units) away from the limit.
By their numbers in this assay, from the lowest: compounds 1 and 3 (each within the scatter of the next); then compound 2. At a limit, below all of these: compound 4.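

In this assay, compound 4 is reported only as a limit, < 14 mL.min-1.g-1. The position therefore tolerates 1,3-benzoxazol-5-yl, with its five-membered aromatic ring added to the six-membered one and no hydrogen-bond donor, without any rise in the number: an at least 1.5-fold lower number from compound 3 to compound 4 (0.19 log units; that floor lies within the scatter) and an at least 1.4-fold lower number from compound 1 to compound 4 (0.15 log units; that floor lies within the scatter) have floors within the scatter, whereas an at least 6.1-fold lower number from compound 2 to compound 4 (0.78 log units; beyond the scatter) lies beyond it. The full size of these steps remains hidden at the limit: the limit of < 14 mL.min-1.g-1 in this assay, at which 1 of the 4 values shown sits.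

The compounds shown leave open whether the ring nitrogen or the ring oxygen of the 1,3-benzoxazol-5-yl group matters. They also leave open how a 2-methoxyphenyl or a pyridine at this position would compare.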